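The source may hold more compounds than are shown below. What is called first, only, known or untested is meant among the compounds shown, and "the series" means these compounds.

In a functional assay on HeLa cells (Homo sapiens) for antiproliferative activity, read by CCK-8 assay, with a stated time of 48 h (a higher number here means a weaker inhibitor, a lower number a stronger inhibitor), compound 3 `COc1ccc(/C=C\c2cc(OC)c(OC)c(OC)c2)cc1OCc1ccc(CNCCNC(C)=O)cc1` gives 6400 nM, and compound 2 `COc1ccc(/C=C\c2cc(OC)c(OC)c(OC)c2)cc1OCc1ccc(CO)cc1` gives 7600 nM. These two values sit within the scatter of each other, the step being a 1.2-fold lower number from compound 2 to compound 3 (0.07 log units; within the scatter). Compound 1 `COc1ccc(/C=C\c2cc(OC)c(OC)c(OC)c2)cc1OCc1ccc(CN2CC[C@H](C(=O)O)C2)cc1` gives > 10000 nM, which is a limit of the assay and not a number. All three share one core and differ only in the group on a saturated chain carbon bound to an aromatic carbon.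

Compound 4 `COc1ccc(/C=C\c2cc(OC)c(OC)c(OC)c2)cc1OCc1ccc(CN2CCCCC2C(=O)NCCN)cc1` keeps that core and changes the same place, where 2-((2-aminoethyl)carbamoyl)piperidin-1-yl stands in place of (2-acetamidoethyl)amino: 2-((2-aminoethyl)carbamoyl)piperidin-1-yl in place of (2-acetamidoethyl)amino on a saturated chain carbon bound to an aromatic carbon. Within the data shown here, three measured steps bear on this change. Among the measured compounds shown here, the only one between two real numbers is a 1.2-fold lower number from compound 2 to compound 3 (0.07 log units; within the scatter), and it stays within the scatter. The other two, an at least 1.3-fold lower number from compound 1 to compound 2 (0.11 log units; that floor lies within the scatter) and an at least 1.5-fold lower number from compound 1 to compound 3 (0.19 log units; that floor lies within the scatter), are only floors set by a limit, and those floors also lie within the scatter. No measured change at this place has therefore moved a number beyond the scatter, although compound 1, which also carries a ring here, reached the limit. The expected change is a 1.1-fold higher number from compound 3 to compound 4 (0.04 log units; within the scatter), which means no step beyond the scatter, with some chance that only a limit is reported. For compound 4 the estimated value is 7000 nM, with an expected range from 2500 nM to 20000 nM.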

Compound 4, half-maximal inhibitory concentration: 7300 nM
Beside the measured number, compound 4's estimate is 1.0-fold (0.02 log units) below it, within the range that was stated.
By their numbers in this assay, from the lowest: compounds 3, 4 and 2 (each within the scatter of the next). At a limit, above all of these: compound 1.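

In this assay, 2-((2-aminoethyl)carbamoyl)piperidin-1-yl in place of (2-acetamidoethyl)amino gives a 1.1-fold higher number from compound 3 to compound 4 (0.06 log units; within the scatter), and in place of hydroxy it gives a 1.0-fold lower number from compound 2 to compound 4 (0.02 log units; within the scatter), so a group with a six-membered non-aromatic ring and 12 heavy atoms leaves the number where the two ring-free groups had it. A ring on this saturated chain carbon bound to an aromatic carbon therefore does not by itself bring a compound to the limit, which compound 1 alone might have suggested. Compound 1 remains a limit and not a number, so the step to compound 4 is only a floor, an at least 1.3-fold lower number from compound 1 to compound 4 (0.13 log units; that floor lies within the scatter), and even this pair is not shown to differ beyond the scatter: the limit of > 10000 nM in this assay, at which 1 of the 4 values shown sits.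

From the compounds shown here alone, it remains open whether the carboxylic acid or the pyrrolidine ring in 3-carboxypyrrolidin-1-yl goes with the limit of compound 1. Going by these compounds, it is also open whether any other group at this place, such as a dimethylamino group, a morpholin-4-yl ring or a longer chain ending in a carboxylic acid, would move the number beyond the scatter.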